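From Fluoro to Hydroxy in a Growth-Inhibiting Series

A few compounds are considered here, and "the series" means these few. Any claim that something is new, unique, unknown or untested is made for them only; others in the source may bear on it.

Three related compounds have been measured in a functional assay on BHK-21 cells (Mesocricetus auratus) for antiproliferative activity, read by sulforhodamine B assay, with a stated time of 48 h, tested at 1 uM; a lower number here means less inhibition of growth, a higher number more inhibition of growth at the concentration tested. Compound 1 `Cc1occc1-c1nn2c(-c3ccncc3)nnc2s1` gives 57%, compound 3 `c1ccc2c(C3=Nn4c(nnc4-c4ccncc4)SC3)cccc2c1` gives 60.7%, and compound 2 `Fc1ccc(OCc2nn3c(-c4ccncc4)nnc3s2)cc1` gives 45.4%. Compound 2 is therefore the lowest of the three, beyond the scatter from both others. Compound 4 `Oc1ccc(OCc2nn3c(-c4ccncc4)nnc3s2)cc1` differs from it in one place, with hydroxy in place of fluoro on an aromatic carbon, para to a large group (hydroxy in place of fluoro on an aromatic carbon). Among the compounds with values here, no measured pair shows this change, so the expectation is loose: a small rise in this assay, not beyond the scatter. The estimated change is a number 4.6 percentage points higher from compound 2 to compound 4 (within the scatter). For compound 4 the expected value is 50%, within an estimated range of 37% to 63%.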

Compound 4, percent growth inhibition at one concentration: 53.7%
Compound 4: middle estimate off by 3.7 percentage points, on the low side, and the stated range covers the measured number.
By their numbers in this assay, from the lowest: compounds 2, 4, 1 and 3 (each within the scatter of the next, the first and the last beyond it).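

In this assay, hydroxy in place of fluoro on an aromatic carbon gives a number 8.3 percentage points higher from compound 2 to compound 4 (within the scatter), so at this position the two groups cannot be told apart in this read-out. Within the data shown here, the earlier compounds offered no pair differing in one place, and this step is the first such reading. Nothing measured here bears on the reason for this outcome. What the compounds shown leave open is how an amine, a methoxy group or a carboxylic acid would read at this same position. They also leave open whether the step would hold on the cores of compound 1 or compound 3.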